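This account rests on a few compounds, and the source may have more. Where it says the series, first, only, none or still open, it means among the compounds named here.

Working notes on the series, measured in a functional assay on the whole organism with Rattus norvegicus as the target; on this read-out lower numbers stand for an effect already at smaller amounts and higher numbers for an effect only at larger amounts of compound.

Of the compounds shown here, three have numbers so far. Compound 1 `CCOC(=O)C(=O)Nc1nc(-c2cccc(O)c2)cs1` carries a hydroxy on its phenyl ring. For compound 1 only a limit of the assay is recorded, > 10 mg/kg, and not a number. Compound 2 `CCOC(=O)C(=O)Nc1nc(-c2ccc(O)cc2)cs1` has the same atoms as compound 1 joined differently; the difference between the two cores is not broken down here. In this assay compound 2 gives about 15 mg/kg. Compound 3 `CCOC(=O)C(=O)Nc1nc(-c2cccc(OC)c2)cs1` is compound 1 after the change (methyl in place of hydrogen on an oxygen on an aromatic ring), and in this assay compound 3 gives about 20 mg/kg. The step that the limit leaves unreadable from compound 1 to compound 3 cannot be sized because the limit of > 10 mg/kg in this assay, at which 1 of the 3 values shown sits, is all that stands for compound 1. Compound 2 and compound 3 lie within the scatter of each other, so no order between them is read.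

Compound 4 `CCOC(=O)C(=O)Nc1nc(-c2ccc(OC)cc2)cs1` is not yet measured. It differs from compound 2 by methyl in place of hydrogen on an oxygen on an aromatic ring, the same change already made from compound 1 to compound 3, at a place described in the same words. Since that earlier step is unreadable, the expectation for compound 4 rests only on compound 2 at about 15 mg/kg and on the pair compound 2 and compound 3 sitting close together. The step from compound 2 to compound 4 is expected to be a 1.3-fold higher number from compound 2 to compound 4 (0.12 log units; within the scatter). Compound 4 is thus estimated at 20 mg/kg, expected between 8 mg/kg and 50 mg/kg.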

Compound 4, dose for half-maximal effect: about 10 mg/kg
Beside the measured number, compound 4's estimate is 2.0-fold (0.30 log units) above it; the measured number falls inside the stated range.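

In this assay the change of hydroxy to methoxy reads as a 1.5-fold lower number from compound 2 to compound 4 (0.18 log units; within the scatter), so on the core of compound 2 no change in the number can be read from placing methyl in place of hydrogen on the oxygen. The same change on the core of compound 1, which leads to compound 3, cannot be read, because only a limit of the assay stands for compound 1 and not a number: the limit of > 10 mg/kg in this assay, at which 1 of the 4 values shown sits. The series therefore holds a single readable step for this change, and that step alone does not show whether the change carries from one core to the other, either as a match between the two cores or as a difference.

Going by these compounds, it remains open whether an amine or a carboxylic acid in place of the hydroxy, or a chain longer than methyl on that oxygen, would move the number in this assay beyond the scatter on either core. All four compounds also share the rest of their structure, which leaves open what a change to that shared part would do in this assay.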